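A Benzyl Swap Starting From an Assay Limit

The compounds below may be only part of what the source reports. "The series", "measured", "known", "first", "only" and "open" are said of these compounds alone.

- Compound 1 (`COc1ccc2cc([C@H](C)c3nnc(SCc4ccc(Cl)cc4)n3-c3ccc(F)cc3)ccc2c1`): > 400000 nM
- Compound 2 (`COc1cccc(CSc2nnc([C@@H](C)c3ccc4cc(OC)ccc4c3)n2-c2ccc(Cl)cc2)c1`): 162000 nM
- Compound 3 (`COc1ccc2cc([C@H](C)c3nnc(SCc4ccc(F)cc4)n3-c3ccc(Cl)cc3)ccc2c1`): 33900 nM

These results come from a functional assay on LNCaP cells (Homo sapiens) for cytotoxicity, read by MTT assay (a lower number here means a stronger inhibitor, a higher number a weaker inhibitor), and they set the scene for one untested change. Compound 1 stands at the limit of > 400000 nM in this assay, at which 1 of the 3 values shown sits, and this is a limit, not a number.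

Compound 4 (`COc1ccc2cc([C@H](C)c3nnc(SCc4c(C)cc(C)cc4C)n3-c3ccc(F)cc3)ccc2c1`) differs from compound 1 in one group: 2,4,6-trimethylphenyl in place of 4-chlorophenyl on a saturated chain carbon bound to a sulfur. Cut one bond further out, this reads 4-chlorobenzyl to 2,4,6-trimethylbenzyl. Among the measured compounds shown here, the counted difference is 2,4,6-trimethylphenyl in place of 4-chlorophenyl on a saturated chain carbon bound to a sulfur and it is the only change.

For the measured compounds named here, one measured step bears on this place: a 4.8-fold lower number from compound 2 to compound 3 (0.68 log units; beyond the scatter) is modest but beyond the scatter. It shows that the group at this position can move the number, although it involves neither group in the present change. Its size therefore offers only a rough guide, and a modest move to a lower number is expected. For compound 4 the expected step is an at least 2.3-fold lower number from compound 1 to compound 4 (0.37 log units; beyond the scatter) and the true size remains uncertain, since the starting point is a limit. Another limit would be no surprise. In this assay the estimate for compound 4 is 170000 nM with an expected range from 40000 nM to 400000 nM.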

Compound 4, half-maximal inhibitory concentration: 2210 nM
The estimate for compound 4 lay 77-fold (1.89 log units) above the measured number; measured number below the stated range.
By their numbers in this assay, from the lowest: compound 4; then compound 3; then compound 2. At a limit, above all of these: compound 1.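

In this assay, among the compounds shown here, this position can do far more than the earlier compounds suggested: putting 2,4,6-trimethylphenyl in place of 4-chlorophenyl on a saturated chain carbon bound to a sulfur gives an at least 180-fold lower number from compound 1 to compound 4 (2.25 log units; beyond the scatter), a large step, whereas the only earlier step at this position was a 4.8-fold lower number from compound 2 to compound 3 (0.68 log units; beyond the scatter). A change in this one group, with the rest of the molecule left as it is, is enough to turn a limit into a measured number. The full size of the step stays unknown because the starting point, compound 1, has a limit and not a number: the limit of > 400000 nM in this assay, at which 1 of the 4 values shown sits.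

What the compounds shown leave open is whether the step needs all the methyl groups of the 2,4,6-trimethylphenyl or only some of them, a question that a plain phenyl or a 4-methylphenyl in the same place would help to answer. Also open, as far as these compounds go, is whether the same 2,4,6-trimethylphenyl would give a step of similar size on the core of compound 3, which carries a 4-chlorophenyl where compound 4 has a 4-fluorophenyl.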